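Swapping the Aryl Group: Compound 2 to Compound 3

A few compounds are considered here, and "the series" means these few. Any claim that something is new, unique, unknown or untested is made for them only; others in the source may bear on it.

compound 1 `CCOC(=O)C1=C(Nc2ccccc2)S/C(=C\c2ccc(OC)cc2)C1=O`: 32.9%
compound 2 `CCOC(=O)C1=C(Nc2ccccc2)S/C(=C\c2ccccc2O)C1=O`: 89.4%

In a functional assay on JAR cells (Homo sapiens) for inhibition, read by MTT assay, with a stated time of 72 h, tested at 10 uM (on this read-out higher numbers stand for more inhibition at the one concentration tested (going by the name of the read-out) and lower numbers for less inhibition), compound 2 gives 89.4%, the highest of the two numbers, while compound 1 gives 32.9%. Compound 3 `CCOC(=O)C1=C(Nc2ccccc2)S/C(=C\c2ccc[nH]2)C1=O` differs from compound 2 by 1H-pyrrol-2-yl in place of 2-hydroxyphenyl on a double-bonded chain carbon bound to a double-bonded ring carbon. Among the measured compounds shown here, the only measured step, a number 56.5 percentage points higher from compound 1 to compound 2 (beyond the scatter), alters the same position but between other groups: it shows that this position moves the read-out strongly, yet gives no direct guide for 1H-pyrrol-2-yl, which keeps one hydrogen-bond donor and loses the acceptor. A downward step beyond the scatter is therefore expected, a number 34.4 percentage points lower from compound 2 to compound 3 (beyond the scatter), with wide uncertainty. Compound 3 is estimated at 55%, between 25% and 85%.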

Compound 3, a percentage reported as inhibition, at one concentration (the size of the read-out at that concentration, not a potency): 49.2%
Estimate against measurement, compound 3: 5.8 percentage points above, within the range that was stated.
By their numbers in this assay, from the lowest: compound 1; then compound 3; then compound 2.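

In this assay, 1H-pyrrol-2-yl in place of 2-hydroxyphenyl gives a number 40.2 percentage points lower from compound 2 to compound 3 (beyond the scatter) while the same group in place of 4-methoxyphenyl gives a number 16.3 percentage points higher from compound 1 to compound 3 (beyond the scatter) at this place on the double-bonded chain carbon. The hydrogen-bond donor count of 2-hydroxyphenyl is kept in 1H-pyrrol-2-yl, so keeping that count alone does not hold the level of compound 2. No evidence at hand accounts for either step. Still open, as far as these compounds go, is whether an amine or a carboxylic acid in place of the hydroxyl on the phenyl ring would hold that level.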